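This account rests on a few compounds, and the source may have more. Where it says the series, first, only, none or still open, it means among the compounds named here.

Measured so far in a functional assay on A549 cells (Homo sapiens) for antiproliferative activity, read by MTT assay, with a stated time of 48 h; on this read-out higher numbers stand for weaker inhibition and lower numbers for stronger inhibition:
- compound 1 `O=C(/C=C\Nc1ccc(Cl)cc1)c1cn(-c2ccccc2)nc1-c1ccccc1`: 14100 nM
- compound 2 `COc1ccc(N/C=C\C(=O)c2cn(-c3ccccc3)nc2-c2ccccc2)cc1`: 3250 nM

Of the two, compound 2 has the lower number, at 3250 nM, and so the stronger inhibition, while compound 1 stands at 14100 nM. The next compound, compound 3 `COc1ccc(N/C=C\C(=O)c2cn(-c3ccccc3)nc2-c2ccc(Cl)cc2)cc1`, keeps the methoxy of compound 2 and turns a phenyl into 4-chlorophenyl. This puts chloro in place of hydrogen on an aromatic carbon, para to a large group: chloro in place of hydrogen on an aromatic carbon.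

Among the measured compounds shown here, only one measured step bears on this change, and only loosely. It is a 4.3-fold lower number from compound 1 to compound 2 (0.64 log units; beyond the scatter), a modest step beyond the scatter, made by methoxy in place of chloro on an aromatic carbon. That step involves chloro, but at a different place in the molecule, and no chloro has yet been measured at the new place. It therefore gives no firm direction in this assay. The step expected is none beyond the scatter, an estimated 1.1-fold lower number from compound 2 to compound 3 (0.03 log units; within the scatter). For compound 3 the estimated value is 3000 nM, with an expected range of 1000 nM to 9500 nM.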

Compound 3, half-maximal inhibitory concentration: 6460 nM
Estimate against measurement, compound 3: 2.2-fold (0.33 log units) below; measured number inside the range.
By their numbers in this assay, from the lowest: compounds 2 and 3 (each within the scatter of the next); then compound 1.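

In this assay, among the compounds shown here, this is the first reading at this position, and chloro in place of hydrogen on an aromatic carbon, para to a large group, gives a 2.0-fold higher number from compound 2 to compound 3 (0.30 log units; within the scatter). The change from phenyl to 4-chlorophenyl therefore stays within the scatter, so compound 2 and compound 3 cannot be told apart here, and this place on the shared core tolerates one chlorine without a step beyond the scatter, something the earlier step, a 4.3-fold lower number from compound 1 to compound 2 (0.64 log units; beyond the scatter), made at a different place, could not show. No measurement given here bears on why this step is as small as it is.

Going by these compounds, whether a different group at this same place, such as an amine, a carboxylic acid or a longer chain like butyl, would give a step beyond the scatter remains open, since a single chloro defines only one point at this position. Also open, on these data alone, is whether 4-chlorophenyl would give a similar step alongside the chloro of compound 1 rather than the methoxy of compound 2, and whether the same holds in any other assay or cell line.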